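Swapping Bromo for Furan-2-yl at a Fused-Ring Carbon

A few compounds are considered here, and "the series" means these few. Any claim that something is new, unique, unknown or untested is made for them only; others in the source may bear on it.

Two measured compounds share one fused core and differ at a single aromatic carbon. Compound 1 `CCCn1cnc2c(N)nc(NCc3ccccc3)nc21` carries a hydrogen there, and in an assay on CHO cells for displacement of a labelled ligand from adenosine receptor A1 (Homo sapiens) (on this read-out lower numbers stand for stronger inhibition and higher numbers for weaker inhibition), compound 1 gives 7600 nM. Compound 2 `CCCn1c(Br)nc2c(N)nc(NCc3ccccc3)nc21` carries a bromo group at that carbon instead, and in this assay compound 2 gives 358 nM. The move between them is a single step: a 21-fold lower number from compound 1 to compound 2 (1.33 log units; beyond the scatter). Among the measured compounds shown here, of the two numbers measured, compound 2 therefore has the lowest, with compound 1 as its only neighbour.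

Compound 3 `CCCn1c(-c2ccco2)nc2c(N)nc(NCc3ccccc3)nc21` changes the same carbon once more: furan-2-yl in place of bromo on an aromatic carbon. For the measured compounds named here, only one measured step speaks to this spot, the large gain seen when bromo replaced hydrogen, and it shows that occupying this carbon with something other than hydrogen helps. Going by the values given here, no measured pair shows what a ring at this carbon does, so the direction of the next step is uncertain; a modest further gain or no step beyond the scatter seems most plausible. Compound 3 is expected to give about 150 nM, within a likely range from 30 nM to 800 nM. This estimate corresponds to an expected step from compound 2 to compound 3 of a 2.4-fold lower number from compound 2 to compound 3 (0.38 log units; beyond the scatter).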

Compound 3, inhibition constant: 138 nM
The estimate for compound 3 lay 1.1-fold (0.04 log units) above the measured number; measured number inside the range.
By their numbers in this assay, from the lowest: compound 3; then compound 2; then compound 1.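

In this assay, furan-2-yl in place of bromo gives a 2.6-fold lower number from compound 2 to compound 3 (0.41 log units; beyond the scatter) and so extends the trend at this carbon: a five-membered aromatic ring with more heavy atoms than bromo is accepted here, and the number falls further rather than climbing back. Measured against the hydrogen compound, the same ring gives a 55-fold lower number from compound 1 to compound 3 (1.74 log units; beyond the scatter) in total, which makes hydrogen, bromo and furan-2-yl an ordered series of three, with most of the overall drop already present in the first step, a 21-fold lower number from compound 1 to compound 2 (1.33 log units; beyond the scatter) as it stands. There is no outside measurement to explain why furan-2-yl gives the lowest number of the three.

As far as these compounds go, what a phenyl ring, an amine or a longer chain such as butyl would do at this same carbon remains open, and so does whether the ring oxygen of furan-2-yl plays any part in the result. From the compounds shown here alone, it is also open whether the order of hydrogen, bromo and furan-2-yl would hold with a group other than propyl on the neighbouring ring atom, or with something other than the benzylamino chain on the shared core.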